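The compounds below may be only part of what the source reports. "The series", "measured", "known", "first", "only" and "open" are said of these compounds alone.

Measured in a functional assay on HT-29 cells (Homo sapiens) for cytotoxicity, read by MTT assay; a higher number here means a weaker inhibitor, a lower number a stronger inhibitor:
- compound 1 `C=C1C(=O)[C@]23C[C@@]1(Cl)CC[C@H]2[C@@]12C=CC(=O)[C@](C)(C(=O)O1)[C@H]2[C@@H]3C(=O)OCc1ccccc1`: 4500 nM
- compound 2 `C=C1C(=O)[C@]23C[C@@]1(O)CC[C@H]2[C@@]12C=CC(=O)[C@](C)(C(=O)O1)[C@H]2[C@@H]3C(=O)OCc1ccccc1`: 83300 nM
- compound 3 `C=C1C(=O)[C@]23C[C@@]1(F)CC[C@H]2[C@@]12C=CC(=O)[C@](C)(C(=O)O1)[C@H]2[C@@H]3C(=O)OC`: 72700 nM

Compound 3 lies within the scatter of compound 2, and the numbers of both sit far above that of compound 1. The next compound to be tested is compound 4 `C=C1C(=O)[C@]23C[C@@]1(F)CC[C@H]2[C@@]12C=CC(=O)[C@](C)(C(=O)O1)[C@H]2[C@@H]3C(=O)OCc1ccccc1`. It keeps everything in compound 3 except that methoxycarbonyl becomes benzyloxycarbonyl, which means phenyl in place of hydrogen on a saturated chain carbon bound to an oxygen next to a carbonyl group.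

Within the data shown here, no measured step makes this change, so nothing bears on it directly. Among the measured compounds shown here, the only step available is hydroxy in place of chloro on a saturated ring carbon, a 19-fold higher number from compound 1 to compound 2 (1.27 log units; beyond the scatter). That large step shows how far one swap can move the number in this series, but it is a different change at a different place. Compounds 1 and 2 both carry benzyloxycarbonyl, yet compound 1 gives 4500 nM and compound 2 gives 83300 nM. This group therefore does not settle the number by itself, and a modest move towards a lower number is only a tentative expectation. The expected change is a 2.4-fold lower number from compound 3 to compound 4 (0.38 log units; beyond the scatter). In this assay, compound 4 is estimated at 30000 nM, with an expected range from 7000 nM to 100000 nM.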

Compound 4, half-maximal inhibitory concentration: 59100 nM
Compound 4: the middle estimate sits 2.0-fold (0.29 log units) below what was measured; the measured number falls inside the stated range.
By their numbers in this assay, from the lowest: compound 1; then compounds 4, 3 and 2 (each within the scatter of the next).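

With fluoro on the saturated ring carbon, exchanging methoxycarbonyl for benzyloxycarbonyl has no effect that can be told from the scatter in this assay (a 1.2-fold lower number from compound 3 to compound 4 (0.09 log units; within the scatter)). Compound 4 also allows fluoro to be compared with the other two ring-carbon groups while benzyloxycarbonyl stays fixed: fluoro and hydroxy cannot be told apart (a 1.4-fold lower number from compound 2 to compound 4 (0.15 log units; within the scatter)), whereas the change from chloro is large (a 13-fold higher number from compound 1 to compound 4 (1.12 log units; beyond the scatter)). Among the three compounds with benzyloxycarbonyl, the chloro compound therefore stands alone, and the large differences seen so far follow the group on the saturated ring carbon rather than the change from methyl to benzyl.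

The data shown give no explanation for why chloro differs from fluoro and hydroxy here. As far as these compounds go, it remains open whether methyl to benzyl would also stay within the scatter with chloro on the ring carbon, and what bromo or an amine at that same ring carbon would give.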